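Chloro added to the second aryl ring of compound 2

A few compounds are considered here, and "the series" means these few. Any claim that something is new, unique, unknown or untested is made for them only; others in the source may bear on it.

Measured compounds:
compound 1 `O=C(NOCc1ccccc1)c1cn(-c2ccccc2)nc1-c1ccccc1` 8830 nM
compound 2 `O=C(NOCc1ccccc1F)c1cn(-c2ccccc2)nc1-c1ccccc1` 11800 nM
compound 3 `O=C(NOCc1ccc(Cl)cc1Cl)c1cn(-c2ccccc2)nc1-c1ccccc1` 5100 nM

All three were run in a functional assay on HeLa cells (Homo sapiens) for antiproliferative activity, read by MTT assay, with a stated time of 48 h, in the presence of a further agent that is not named here; on this read-out lower numbers stand for stronger inhibition of growth and higher numbers for weaker inhibition of growth. Compound 2 gives the highest number of the three; one of its steps is a 1.3-fold higher number from compound 1 to compound 2 (0.13 log units; within the scatter), within the scatter, and the other is a 2.3-fold lower number from compound 2 to compound 3 (0.36 log units; beyond the scatter), a modest one beyond the scatter.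

Compound 4 `O=C(NOCc1ccccc1F)c1cn(-c2ccccc2)nc1-c1ccc(Cl)cc1` is not yet measured. It differs from compound 2 by chloro in place of hydrogen on an aromatic carbon, on the aryl ring attached to the shared core rather than on the benzyl group.

Among the compounds with values here, no measured step changes that ring. The steps that add chlorine at all, a 1.7-fold lower number from compound 1 to compound 3 (0.24 log units; within the scatter) and a 2.3-fold lower number from compound 2 to compound 3 (0.36 log units; beyond the scatter), place it on the benzyl ring and give at most a modest lowering of the number; they bear on compound 4 only loosely. On that basis, no step beyond the scatter is expected from compound 2 to compound 4, with the step estimated as a 1.3-fold lower number from compound 2 to compound 4 (0.12 log units; within the scatter). Compound 4 is therefore expected to give about 9000 nM in this assay, within a range of 3500 nM to 25000 nM.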

Compound 4, concentration for 50% growth inhibition: 4170 nM
Compound 4: the middle estimate sits 2.2-fold (0.33 log units) above what was measured; measured number inside the range.
By their numbers in this assay, from the lowest: compounds 4, 3, 1 and 2 (each within the scatter of the next, the first and the last beyond it).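

Within the data shown here, the aryl ring attached to the shared core, which no earlier step touched, responds to substitution in this assay: phenyl to 4-chlorophenyl gives a modest step beyond the scatter (a 2.8-fold lower number from compound 2 to compound 4 (0.45 log units; beyond the scatter)). On the benzyl ring, chlorine gave a step beyond the scatter in only one of two cases (a 2.3-fold lower number from compound 2 to compound 3 (0.36 log units; beyond the scatter)), while the other stayed within it (a 1.7-fold lower number from compound 1 to compound 3 (0.24 log units; within the scatter)); compound 4 shows that a single chloro on this other ring can also lower the number beyond the scatter. No measurement at hand accounts for this step.

The compounds shown leave open whether chloro here gives a similar step with the unsubstituted benzyl group of compound 1 or the 2,4-dichlorobenzyl group of compound 3. Also open, going by these compounds, is how this position would respond to an amine, a methoxy group or a carboxylic acid in place of chloro.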